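The compounds below may be only part of what the source reports. "The series", "measured", "known", "first", "only" and "open" are said of these compounds alone.

Measured compounds:

Compound 1 `CCCCc1ccc2c(c1)C(=O)C(=O)N2`: in a functional assay on HepG2 cells (Homo sapiens) for antiproliferative activity, read by MTT assay, with a stated time of 48 h (a lower number here means a stronger inhibitor, a higher number a weaker inhibitor), compound 1 gives > 10000 nM, which is a limit of the assay and not a number.
Compound 2 `COc1ccc(CN2C(=O)C(=O)c3c(-c4ccc(OC)cc4)cccc32)cc1`: compound 2 gives > 10000 nM, again a limit rather than a number.
Compound 3 `COc1ccc(CN2C(=O)C(=O)c3cc(-c4cc(OC)cc(OC)c4)ccc32)cc1`: compound 3 gives 1200 nM.

Going by the values given here, compound 3 therefore stands alone as the only real number in this set; the other two compounds sit at the limit of > 10000 nM in this assay, at which 2 of the 3 values shown sit, so nothing can be said about how far apart they are, only that compound 3 is the one that registered.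

Compound 4 `COc1ccc(CN2C(=O)C(=O)c3cc(-c4ccncc4)ccc32)cc1` is not yet measured. It differs from compound 3 in one place: pyridin-4-yl in place of 3,5-dimethoxyphenyl on an aromatic carbon. Among the compounds with values here, no pair of measured compounds differs in exactly one place, so there is no measured step to lean on. The expectation is that the step from compound 3 to compound 4 a 2.9-fold higher number from compound 3 to compound 4 (0.46 log units; beyond the scatter) is toward weaker inhibition, somewhat beyond the usual scatter, with a real chance that compound 4 ends at a limit. Compound 4 is estimated at 3500 nM, expected to lie between 900 nM and 15000 nM.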

Compound 4, half-maximal inhibitory concentration: > 10000 nM
Compound 4 ended at the assay's limit; the forecaster's own chance of this, stated with the estimate: 40%; at least 2.8-fold (0.45 log units) between middle value and limit.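

Going by these compounds alone, this is the first step between two measured compounds in the set, and it shows that the group on this aromatic carbon of the shared core matters in this assay: putting pyridin-4-yl in place of 3,5-dimethoxyphenyl gives an at least 8.3-fold higher number from compound 3 to compound 4 (0.92 log units; beyond the scatter). The activity of compound 3 therefore does not survive every aromatic ring at this position. The value of compound 4 is a limit of the assay and not a number, so the full size of the step stays unknown: the limit of > 10000 nM in this assay, at which 3 of the 4 values shown sit.

The change removes the methoxy groups and brings in a ring nitrogen in one move, and it remains open which of the two accounts for the loss. Going by these compounds, a plain phenyl ring would help separate them, and how an amine or a carboxylic acid on this ring would behave also remains open.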